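Acyl replacement on the shared core: compound 4

The source may report more compounds than this note shows. Statements on the series, on what has been measured and on what is new or still open speak of the compounds shown alone.

Measured in a functional assay on NUGC-3 cells (Homo sapiens) for cytotoxicity, read by sulforhodamine B assay, with a stated time of 72 h; a lower number here means a stronger inhibitor of growth, a higher number a weaker inhibitor of growth:
compound 1 `O=C(Nc1cc(C(F)(F)F)cc(C(F)(F)F)c1)C1CCc2ccccc2N1C(=O)c1ccc(Cl)cc1` gives 1660 nM
compound 2 `O=C(Nc1ccccc1C(F)(F)F)C1CCc2ccccc2N1C(=O)c1ccccc1Cl` gives 2730 nM
compound 3 `O=C(Nc1ccccc1O)C1CCc2ccccc2N1C(=O)c1cccc(Cl)c1` gives 11000 nM

Compound 1 stands at the lowest of the three numbers shown, though compound 2 sits within the scatter of it and the two cannot be ordered. Compound 3 gives a higher number than compound 1, beyond the scatter.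

Compound 4 `CCC(=O)N1c2ccccc2CCC1C(=O)Nc1cc(C(F)(F)F)cc(C(F)(F)F)c1` differs from compound 1 in one place: ethyl in place of 4-chlorophenyl on a carbonyl carbon. Going by the values given here, no measured pair carries that change, so no step can be read off for it. The expectation for compound 4 is a weaker inhibitor than compound 1, with a step of a 3.3-fold higher number from compound 1 to compound 4 (0.52 log units; beyond the scatter), beyond the scatter. The estimate for compound 4 in this assay is 5500 nM, with a range from 1800 nM to 20000 nM.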

Compound 4, concentration for 50% growth inhibition: 7220 nM
Estimate against measurement, compound 4: 1.3-fold (0.12 log units) below; low and high end bracket the measured number.
By their numbers in this assay, from the lowest: compounds 1 and 2 (each within the scatter of the next); then compounds 4 and 3 (each within the scatter of the next).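

In this assay, going by these compounds alone, ethyl in place of 4-chlorophenyl on a carbonyl carbon gives a 4.3-fold higher number from compound 1 to compound 4 (0.64 log units; beyond the scatter) and this is the first single-place step, showing that the acyl group at this position matters to growth inhibition. Compound 4 still gives 7220 nM so growth inhibition survives the loss of the aromatic ring. Nothing measured here accounts for this step.

Going by these compounds, whether the ring or its chlorine carries the step stays open; unsubstituted benzoyl, cyclohexanecarbonyl or a longer chain such as butanoyl on the same carbonyl carbon would separate these. On these data alone, whether the step holds with the other anilide groups is also open.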